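The source may hold more compounds than are shown below. What is called first, only, known or untested is meant among the compounds shown, and "the series" means these compounds.

Measured compounds in a physicochemical assay for lipophilicity, using the shake flask method, at pH 7.4; on this read-out lower numbers stand for lower lipophilicity and higher numbers for higher lipophilicity:
- compound 1 `CC(=O)N1CCN([C@H]2CC[C@H](Nc3ncnn4ccc([C@H]5CC[C@H](C(N)=O)CC5)c34)CC2)CC1`: 1.4
- compound 2 `CN(C)[C@H]1CC[C@H](Nc2ncnn3ccc([C@H]4CC[C@@H](C(N)=O)CC4)c23)CC1`: 0.1

Of these two measurements, compound 2, at 0.1, holds the lower number, and compound 1, at 1.4, lies above it by more than the usual scatter. Attention now turns to compound 3 `Cc1ccn2ncnc(N[C@H]3CC[C@H](N(C)C)CC3)c12`, which has not yet been measured. Relative to compound 2, it carries methyl in place of 4-carbamoylcyclohexyl on an aromatic carbon. Both measured compounds carry the 4-carbamoylcyclohexyl, so neither shows directly what replacing it does, and the estimate remains uncertain. The starting point is compound 2 at 0.1, and no shift beyond the scatter is expected in this assay. The expected change is a number 0.10 log units higher from compound 2 to compound 3 (within the scatter). For compound 3 the estimated value is 0.2, with an expected range from -0.4 to 0.8.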

Compound 3, distribution coefficient: 0.2
Beside the measured number, compound 3's estimate shows no gap at the digits printed; the measured number falls inside the stated range.
By their numbers in this assay, from the lowest: compounds 2 and 3 (each within the scatter of the next); then compound 1.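

For the compounds shown here, the exchange of the 4-carbamoylcyclohexyl for methyl, on an aromatic carbon of a five-membered aromatic ring, gives a number 0.10 log units higher from compound 2 to compound 3 (within the scatter) in this assay and is the first direct reading at this position, since both earlier compounds carry the 4-carbamoylcyclohexyl. A group of 9 heavy atoms, with its carbon ring, hydrogen-bond donor and hydrogen-bond acceptor, gives way here to a single carbon, yet the two numbers cannot be told apart. No measured evidence bears on why this is so.

On these data alone, whether a carboxylic acid, a hydroxymethyl group or a plain cyclohexyl at this position would read the same remains open. Also open, as far as these compounds go, is whether the methyl exchange would give a similar step in the setting of compound 1.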